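This account rests on a few compounds, and the source may have more. Where it says the series, first, only, none or still open, it means among the compounds named here.

Measured compounds:
- compound 1 `CCCC[C@H](NC(=O)OC(C(C)C)C(C)C)C(=O)C(=O)Nc1ccnn1C`: 1700 nM
- compound 2 `CCCC[C@H](NC(=O)OC(C(C)C)C(C)C)C(=O)C(=O)Nc1ccn(C)n1`: 11 nM
- compound 3 `CCCC[C@H](NC(=O)OC(C(C)C)C(C)C)C(=O)C(=O)Nc1[nH]ncc1C`: 5.5 nM

In an assay on isolated protein for inhibition of cathepsin K (Rattus norvegicus) (a higher number here means a weaker inhibitor, a lower number a stronger inhibitor), compound 3 has the lowest number of the three. Its nearest neighbour is compound 2, and the step of a 2.0-fold lower number from compound 2 to compound 3 (0.30 log units; within the scatter) lies within the scatter, so the two cannot be ranked against each other. Compound 1 stands far away: the step of a 310-fold lower number from compound 1 to compound 3 (2.49 log units; beyond the scatter) is large, as is a 150-fold lower number from compound 1 to compound 2 (2.19 log units; beyond the scatter).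

Compound 4 `CCCC[C@H](NC(=O)OC(C(C)C)C(C)C)C(=O)C(=O)Nc1cc[nH]n1` differs from compound 3 by 1H-pyrazol-3-yl in place of 4-methyl-1H-pyrazol-5-yl on an amide-type nitrogen. Compound 4 thus carries neither the methyl on the ring nitrogen that compound 1 and compound 2 carry, nor the methyl on the ring carbon that compound 3 carries. For the measured compounds named here, the steps that bear on this change are the two large ones away from compound 1, which show that the 1-methyl-1H-pyrazol-5-yl arrangement alone gives a high number, and the small step from compound 2 to compound 3, which shows that 1-methyl-1H-pyrazol-3-yl and 4-methyl-1H-pyrazol-5-yl give numbers within the scatter of each other. Compound 4 shares the 1H-pyrazol-3-yl arrangement of compound 2 and compound 3 rather than that of compound 1, so no step beyond the scatter is expected; compound 4 is estimated at 10 nM, within 3 nM to 35 nM, corresponding to an expected step of a 1.8-fold higher number from compound 3 to compound 4 (0.26 log units; within the scatter) in this assay.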

Compound 4, half-maximal inhibitory concentration: 13 nM
Compound 4: the middle estimate sits 1.3-fold (0.11 log units) below what was measured, and the stated range covers the measured number.
By their numbers in this assay, from the lowest: compounds 3, 2 and 4 (each within the scatter of the next, the first and the last beyond it); then compound 1.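

In this assay, the step of a 1.2-fold higher number from compound 2 to compound 4 (0.07 log units; within the scatter) shows that hydrogen can stand in place of the methyl on the aromatic nitrogen of compound 2 with no difference that can be read, so that methyl is not needed for a low number. For the compounds shown here, the step of a 130-fold lower number from compound 1 to compound 4 (2.12 log units; beyond the scatter) adds that the unsubstituted 1H-pyrazol-3-yl group stays far from compound 1, which leaves compound 1, with its 1-methyl-1H-pyrazol-5-yl group, as the only one of these four compounds with a high number. Going by these compounds alone, the step of a 2.4-fold higher number from compound 3 to compound 4 (0.37 log units; beyond the scatter) is modest but beyond the scatter, and it is the first difference that can be read among the three low compounds, although compound 2 cannot be separated from either compound 3 or compound 4. Nothing available here explains these steps.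

Going by these compounds, it remains open whether the methyl on the ring carbon of compound 3 could give way to an ethyl, a chlorine or an amine with a similar number. On these data alone, it is also open whether a longer chain, such as ethyl, on the ring nitrogen would behave as the methyl of compound 2 does.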